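Removing the Methoxy Group From Compound 1

The source may hold more compounds than are shown below. What is called first, only, known or untested is meant among the compounds shown, and "the series" means these compounds.

In an assay on Sf9 cells for inhibition of protein deacetylase HDAC6 (Homo sapiens), read by fluorescence, with a stated time of 40 min (on this read-out lower numbers stand for stronger inhibition and higher numbers for weaker inhibition), compound 1 `COc1ccc(-n2nc(-c3ccccc3)nc2CNc2ccc(C(=O)NO)cc2)cc1` gives 127 nM. Among the three measured compounds it has the second highest number. Compound 3 `O=C(NO)c1ccc(NCc2nc(-c3ccc(F)cc3)nn2-c2ccccc2)cc1` gives 115 nM, a value within the scatter of compound 1, so the two cannot be told apart. Compound 2 `O=C(NO)c1ccc(NCc2nc(-c3ccccc3)nn2-c2ccc(Br)cc2)cc1`, which carries bromo in place of methoxy on an aromatic carbon, gives 1730 nM. That step is a 14-fold higher number from compound 1 to compound 2 (1.13 log units; beyond the scatter).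

Compound 4 `O=C(NO)c1ccc(NCc2nc(-c3ccccc3)nn2-c2ccccc2)cc1` has not yet been measured. Its difference from compound 1 is hydrogen in place of methoxy on an aromatic carbon. Among the compounds with values here, no measured step replaces a methoxy with hydrogen, so nothing bears directly on this change. Within the data shown here, the only step that touches the same methoxy, a 14-fold higher number from compound 1 to compound 2 (1.13 log units; beyond the scatter), shows that altering this group can move the number a great deal, although bromo and hydrogen are different groups, so the size cannot simply be carried over. A moderate rise in the number is therefore expected, with wide uncertainty. Compound 4 is estimated at 260 nM, in a range from 90 nM to 750 nM, which would be a 2.0-fold higher number from compound 1 to compound 4 (0.31 log units; beyond the scatter).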

Compound 4, half-maximal inhibitory concentration: 112 nM
Compound 4: the middle estimate sits 2.3-fold (0.37 log units) above what was measured; the range from low to high includes it.
By their numbers in this assay, from the lowest: compounds 4, 3 and 1 (each within the scatter of the next); then compound 2.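

In this assay, the step of a 1.1-fold lower number from compound 1 to compound 4 (0.05 log units; within the scatter) shows that the 4-methoxyphenyl to phenyl change cannot be told apart from no change, so this position holds its level without the methoxy. The step of a 15-fold lower number from compound 2 to compound 4 (1.19 log units; beyond the scatter) places the large gap on the bromo itself, since hydrogen and methoxy sit together at this position while bromo stands well apart from both. Hydrogen in place of fluoro at another aromatic carbon gives a 1.0-fold lower number from compound 3 to compound 4 (0.01 log units; within the scatter) and so also lies within the scatter, which makes compound 4 a plain reference for both sites.

Going by these compounds, it remains open whether a chloro, an amine or a carboxylic acid at the methoxy position would stay with hydrogen or move toward bromo. Nothing here accounts for why bromo alone stands apart.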